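The source may hold more compounds than are shown below. What is called first, only, known or untested is meant among the compounds shown, and "the series" means these compounds.

Measured compounds:

Compound 1 `Cc1cc(S(=O)(=O)/N=C(\N)n2nccc2-c2ccccc2)c(SCc2ccccc2Cl)cc1Cl`: in a functional assay on HCT-116 cells (Homo sapiens) for cytotoxicity, read by MTT assay, with a stated time of 72 h (a higher number here means a weaker inhibitor, a lower number a stronger inhibitor), compound 1 gives 18000 nM.
Compound 2 `Cc1cc(S(=O)(=O)/N=C(\N)n2nccc2-c2ccccc2)c(SCc2ccccc2C(F)(F)F)cc1Cl`: in this assay compound 2 gives 16000 nM.
Compound 3 `Cc1cc(-c2ccccc2)n(/C(N)=N/S(=O)(=O)c2cc(C)c(Cl)cc2SCc2ccccc2C(F)(F)F)n1`: in this assay compound 3 gives 25000 nM.

The three measured compounds lie close together, and none of them can be called stronger or weaker than another. Compound 3 differs from compound 2 in its core by methyl in place of hydrogen on an aromatic carbon, and that change gave a step of a 1.6-fold higher number from compound 2 to compound 3 (0.19 log units; within the scatter). Compound 1 differs from compound 2 by chloro in place of trifluoromethyl on an aromatic carbon, a change that made a step of a 1.1-fold higher number from compound 2 to compound 1 (0.05 log units; within the scatter).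

Compound 4 `Cc1cc(-c2ccccc2)n(/C(N)=N/S(=O)(=O)c2cc(C)c(Cl)cc2SCc2ccccc2Cl)n1` has not yet been measured. It differs from compound 3 by chloro in place of trifluoromethyl on an aromatic carbon, which is the same change that was made from compound 2 to compound 1, here carried out on the core of compound 3 rather than the core of compound 2. Among the compounds with values here, compound 4 is expected to make a step of a 1.1-fold higher number from compound 3 to compound 4 (0.03 log units; within the scatter) from its parent, because a 1.1-fold higher number from compound 2 to compound 1 (0.05 log units; within the scatter) was within the scatter and there is nothing among the measured compounds to suggest the change would read differently on the other core. Compound 3 at 25000 nM is the starting point for that expectation. Compound 4 is therefore estimated at 27000 nM, with the expected range running from 12000 nM to 55000 nM.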

Compound 4, half-maximal inhibitory concentration: 170000 nM
Compound 4: middle estimate off by 6.3-fold (0.80 log units), on the low side; the whole stated range lies below it.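

In this assay, chloro in place of trifluoromethyl on an aromatic carbon read differently on the two cores, giving a 6.8-fold higher number from compound 3 to compound 4 (0.83 log units; beyond the scatter) on the methyl-bearing core, a clear departure from the earlier step: the same change on two cores in this assay, a 1.1-fold higher number (0.05 log units; within the scatter) from compound 2 to compound 1 and a 6.8-fold higher number (0.83 log units; beyond the scatter) from compound 3 to compound 4, 6.0-fold (0.78 log units) apart, beyond the scatter of two such steps. Seen from the other side of the same four compounds, methyl in place of hydrogen on an aromatic carbon gave a 9.4-fold higher number from compound 1 to compound 4 (0.98 log units; beyond the scatter) in the chloro pair, again apart from the step in the trifluoromethyl pair: the same change on two cores in this assay, a 1.6-fold higher number (0.19 log units; within the scatter) from compound 2 to compound 3 and a 9.4-fold higher number (0.98 log units; beyond the scatter) from compound 1 to compound 4, 6.0-fold (0.78 log units) apart, beyond the scatter of two such steps. Within the data shown here, this shows that neither change can be carried unchanged from one core to the other, but both comparisons rest on the single value of compound 4, so they count as one observation, and they show neither what lies behind the difference nor whether it extends to other compounds.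

The compounds shown leave open whether a bromo or methoxy group in place of chloro on the 2-chlorobenzyl group would follow compound 4 or compound 1. They also leave open whether an ethyl group in place of the added methyl would give a step of similar size on either benzyl series.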